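Thiol end of the series: cytotoxicity outlook

A few compounds are considered here, and "the series" means these few. Any claim that something is new, unique, unknown or untested is made for them only; others in the source may bear on it.

Among the compounds with values here, in an ADME assay (MDM cells, Homo sapiens) for cytotoxicity, read by resazurin assay, with a stated time of 3 days (a higher number here means a weaker inhibitor, a lower number a stronger inhibitor), compound 1 `CCCCSc1nnc(COc2ccccc2C2=NOC(c3ccc(Cl)cc3Cl)C2)n1NC(C)=O` gives 2.6 ug/mL, the only number available so far. Compound 2 `CC(=O)Nn1c(COc2ccccc2C2=NOC(c3ccc(Cl)cc3Cl)C2)nnc1Sc1ccccc1` has no single number to place it on that scale, its entry reading "not determined" (no result reported), so it cannot be ranked against compound 1.

Compound 3 `CC(=O)Nn1c(S)nnc1COc1ccccc1C1=NOC(c2ccc(Cl)cc2Cl)C1` is the next member to be tested. The structural change is hydrogen in place of phenyl on a sulfur, in words hydrogen in place of phenyl on a sulfur.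

Within the data shown here, no measured step exists, so the data cannot set the size of this change in this assay. A modest move toward a higher number, meaning a weaker effect, is expected, and it may not exceed the scatter. Among the measured compounds shown here, the sole numerical anchor is compound 1 at 2.6 ug/mL.

For compound 3 the estimated value is 4 ug/mL, with an expected range of 1.2 ug/mL to 15 ug/mL.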

Compound 3, half-maximal inhibitory concentration: 1.3 ug/mL
The estimate for compound 3 lay 3.1-fold (0.49 log units) above the measured number; the range from low to high includes it.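

In this assay, within the data shown here, the first readable step at this sulfur is small (a 2.0-fold lower number from compound 1 to compound 3 (0.30 log units; within the scatter)), so butyl and hydrogen on the sulfur are not told apart in this read-out, and the sulfur can carry either without a change beyond the scatter. The phenyl to hydrogen change from compound 2 to compound 3 cannot be read, as compound 2 has no result to set against compound 3. No evidence on hand bears on this outcome.

What the sulfur tolerates therefore rests on a single pair, butyl and hydrogen, with the aromatic case unresolved. Still open, as far as these compounds go, is whether a longer chain such as octyl on the sulfur, or a carboxylic acid or an amine carried on a short chain there, would move the number beyond the scatter.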